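Replacing the acetylphenyl ring by pyrazolyl: an expectation

The source may hold more compounds than are shown below. What is called first, only, known or untested is meant among the compounds shown, and "the series" means these compounds.

Three compounds share one core. Compound 1 `CC(=O)N1CCCc2ccc(NC(=O)c3ccc(-c4ccccc4)cc3)cc21` gives 7.2 in a functional assay for antagonist activity at transient receptor potential cation channel subfamily V member 1 (Homo sapiens), read by FLIPR and calcium flux; on this read-out lower numbers stand for lower potency and higher numbers for higher potency (the scale is a negative logarithm). Compound 2 `CC(=O)c1cccc(-c2ccc(C(=O)Nc3ccc4c(c3)N(C)CCC4)cc2)c1` gives 7, and compound 3 `CNS(=O)(=O)c1cccc(-c2ccc(C(=O)Nc3ccc4c(c3)N(C)CCC4)cc2)c1` gives 7. Compound 2 stands level with compound 3, and compound 1 lies within the scatter of both, so nothing separates the three. Within the data shown here, the only step that changes a single place, from compound 2 to compound 3, shows no change at the digits printed from compound 2 to compound 3 (within the scatter): swapping the group on the outer ring left potency untouched. Compound 4 `CN1CCCc2ccc(NC(=O)c3ccc(-n4cccn4)cc3)cc21` differs from compound 2 by 1H-pyrazol-1-yl in place of 3-acetylphenyl on an aromatic carbon. Among the measured compounds shown here, no measured step removes that whole outer ring, so the step from compound 2 to compound 4 is expected to be a number 0.40 log units lower from compound 2 to compound 4 (beyond the scatter), a modest and uncertain loss. Compound 4 is therefore estimated at 6.6, between 6 and 7.2.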

Compound 4, negative logarithm of the antagonist equilibrium constant: 6.9
For compound 4 the middle estimate is 0.30 log units below the measured one; low and high end bracket the measured number.
By their numbers in this assay, from the lowest: compounds 4, 2, 3 and 1 (each within the scatter of the next).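

In this assay, this position takes a far larger swap than the earlier step on the outer ring: 3-acetylphenyl, with 9 heavy atoms, gives way to 1H-pyrazol-1-yl, with 5, and the result is a number 0.10 log units lower from compound 2 to compound 4 (within the scatter). A five-membered aromatic ring with 2 hetero atoms can therefore stand here in place of a six-membered aromatic ring of carbon only, with no measurable cost in potency. No supporting data explain this outcome. As far as these compounds go, it remains open how an amine, a carboxylic acid or a longer chain would read at this place, and so whether an aromatic ring is needed there at all.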